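This account rests on a few compounds, and the source may have more. Where it says the series, first, only, none or still open, it means among the compounds named here.

Notes on an ADME assay on the whole organism (Rattus norvegicus, strain Sprague-Dawley) for pharmacokinetics, using cassette dosing, at a dose of 1 mg/kg by the oral route; a higher number here means that a larger share of the oral dose reaches the circulation, a lower number that a smaller share of the oral dose reaches the circulation: compound 1 `O=C(Nc1ccc2[nH]c(=O)oc2c1)C(=O)N1CCN(c2ccc(C(F)(F)F)cc2)CC1` gives 24.8%, compound 2 `O=C(Nc1ccc2[nH]c(=O)oc2c1)C(=O)N1CCN(c2ccc(F)c(F)c2)CC1` gives 13% and compound 3 `COc1ccc(N2CCN(C(=O)C(=O)Nc3ccc4[nH]c(=O)oc4c3)CC2)cc1F` gives 0.6%, which places compound 2 second highest of the three. Compound 4 `C[C@@H]1CN(c2ccc(F)c(F)c2)CCN1C(=O)C(=O)Nc1ccc2[nH]c(=O)oc2c1` departs from compound 2 by one change: methyl in place of hydrogen on a saturated ring carbon. The measured steps all alter the aromatic group, not the saturated ring: a number 11.8 percentage points lower from compound 1 to compound 2 (beyond the scatter) and a number 12.4 percentage points lower from compound 2 to compound 3 (beyond the scatter), both modest but beyond the scatter. Neither tests methyl in place of hydrogen on a saturated ring carbon, so they indicate only the general size of movement in this series and give no direction. No step beyond the scatter is therefore expected in this assay. The expected step is a number 1 percentage points higher from compound 2 to compound 4 (within the scatter). For compound 4 the estimated value is 14%, with an expected range of 4% to 32%.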

Compound 4, oral bioavailability: 118%
Beside the measured number, compound 4's estimate is 104 percentage points below it; measured number above the stated range.
By their numbers in this assay, from the lowest: compound 3; then compound 2; then compound 1; then compound 4.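

With methyl in place of hydrogen on a saturated ring carbon next to the ring nitrogen, this assay shows a number 105 percentage points higher from compound 2 to compound 4 (beyond the scatter). This single added carbon on the saturated ring therefore moves the read-out far more than the aromatic changes linking compound 1, compound 2 and compound 3, so the ring position is highly sensitive in this series. Nothing shown explains the size of this step.

From the compounds shown here alone, whether the same methyl gives such a step with the 4-(trifluoromethyl)phenyl group of compound 1 remains open. Also open, going by these compounds, is how an ethyl or hydroxymethyl group, or the opposite configuration at this carbon, would read.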